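The compounds below may be only part of what the source reports. "The series", "measured", "known", "first", "only" and "open" are said of these compounds alone.

Compound 1 `Cn1nc2c(=O)n(CC3(O)CCN(Cc4ccc(-c5ccco5)cc4Cl)CC3)cnc2c1-c1ccc(CNC=O)cc1` gives the lowest number of the three measured compounds in an assay on isolated protein for inhibition of ubiquitin carboxyl-terminal hydrolase 7 (Homo sapiens), with stated times of 30 min and 2 h (on this read-out lower numbers stand for stronger inhibition and higher numbers for weaker inhibition), at 20.9 nM. Compound 2 `Cn1nc2c(=O)n(CC3(O)CCN(Cc4ccc(-c5ncco5)cc4Cl)CC3)cnc2c1-c1ccc(CN)cc1` gives 1120 nM in this assay, and compound 3 `Cn1nc2c(=O)n(CC3(O)CCN(Cc4ccc(-c5ccsc5Cl)cc4Cl)CC3)cnc2c1-c1ccc(CN)cc1` gives 453 nM; both carry a free aminomethyl group and a different aryl group, so their gap to compound 1 cannot be assigned to one change. Within the data shown here, the one single-point step, a 2.5-fold lower number from compound 2 to compound 3 (0.39 log units; beyond the scatter), concerns the aryl group and not the amine, so it does not bear on the change to compound 4 `Cn1nc2c(=O)n(CC3(O)CCN(Cc4ccc(-c5ccco5)cc4Cl)CC3)cnc2c1-c1ccc(CNC2CC2)cc1`, which is cyclopropyl in place of formyl on an amine nitrogen. Among the measured compounds shown here, with no measured step on the amine nitrogen, a modest loss is expected, a 2.6-fold higher number from compound 1 to compound 4 (0.42 log units; beyond the scatter), and compound 4 is estimated at 55 nM, within 12 nM to 250 nM.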

Compound 4, half-maximal inhibitory concentration: 54.1 nM
Compound 4: middle estimate off by 1.0-fold (0.01 log units), on the high side; the measured number falls inside the stated range.
By their numbers in this assay, from the lowest: compound 1; then compound 4; then compound 3; then compound 2.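

On the amine nitrogen, the first single-point step shown, a 2.6-fold higher number from compound 1 to compound 4 (0.41 log units; beyond the scatter), is modest but beyond the scatter. Formyl can thus give way to cyclopropyl, which has a ring and no hydrogen-bond acceptor, with only this limited loss in this assay. No supporting data explain the difference. From the compounds shown here alone, it remains open whether an acetyl group, a methyl group or a longer alkyl chain on this nitrogen would give a number nearer that of compound 1 or compound 4. Going by these compounds, the effect of a free amine with the aryl group of these two compounds also remains open.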